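Swapping fluorine for hydroxyl on the anilide ring

The source may report more compounds than this note shows. Statements on the series, on what has been measured and on what is new or still open speak of the compounds shown alone.

Three compounds share one core and differ only in the group carried on the amide nitrogen. Compound 1 `CC1=C(/C=C/C(C)=C/C=C/C(C)=C\C(=O)NCc2ccc(F)cc2)C(C)(C)CCC1n1ccnc1` carries a 4-fluorobenzyl group, compound 2 `CC1=C(/C=C/C(C)=C/C=C/C(C)=C\C(=O)Nc2ccc(F)cc2)C(C)(C)CCC1n1ccnc1` a 4-fluorophenyl group, and compound 3 `CC1=C(/C=C/C(C)=C/C=C/C(C)=C\C(=O)NCc2cccc(F)c2)C(C)(C)CCC1n1ccnc1` a 3-fluorobenzyl group. In a functional assay on MDA-MB-231 cells (Homo sapiens) for inhibition, read by MTT assay (a lower number here means a stronger inhibitor of growth, a higher number a weaker inhibitor of growth), compound 1 gives 1410 nM. Compound 2 gives 4950 nM, the highest of the three numbers. Compound 3 gives 1650 nM. The step of a 3.5-fold higher number from compound 1 to compound 2 (0.55 log units; beyond the scatter) and the step of a 3.0-fold lower number from compound 2 to compound 3 (0.48 log units; beyond the scatter) both set compound 2 apart, while the step of a 1.2-fold higher number from compound 1 to compound 3 (0.07 log units; within the scatter) makes no difference that counts.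

Compound 4 `CC1=C(/C=C/C(C)=C/C=C/C(C)=C\C(=O)Nc2ccc(O)cc2)C(C)(C)CCC1n1ccnc1` keeps the frame of compound 2 and changes a single atom: hydroxy in place of fluoro on an aromatic carbon. Among the measured compounds shown here, none of the measured steps alters a substituent on a ring bound directly to the amide nitrogen; they either move the ring or shift the fluorine on a benzyl group. The measured compounds therefore give no direct guide to this change, and the plainest expectation is a step no larger than the scatter, in either direction. The expected step is a 1.1-fold lower number from compound 2 to compound 4 (0.04 log units; within the scatter). Compound 4 is thus estimated at 4500 nM, with a range from 1500 nM to 13000 nM.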

Compound 4, concentration for 50% growth inhibition: 13100 nM
For compound 4 the middle estimate is 2.9-fold (0.46 log units) below the measured one; measured number outside the range, above it.
By their numbers in this assay, from the lowest: compounds 1 and 3 (each within the scatter of the next); then compound 2; then compound 4.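

In this assay, the substituent on the aromatic ring bound directly to the amide nitrogen matters: a 2.6-fold higher number from compound 2 to compound 4 (0.42 log units; beyond the scatter) shows that hydroxy in place of fluoro, a swap of one heavy atom that adds a hydrogen-bond donor and a hydrogen-bond acceptor, moves the number beyond the scatter. The steps of a 7.9-fold higher number from compound 3 to compound 4 (0.90 log units; beyond the scatter) and a 9.3-fold higher number from compound 1 to compound 4 (0.97 log units; beyond the scatter) are larger, but each also changes a benzyl group to a phenyl group, so neither isolates the hydroxy. No measurement at hand gives a reason for the rise.

From the compounds shown here alone, whether a methoxy or an amine at the same place on the ring would behave more like fluoro or like hydroxy remains open. So does whether a 4-hydroxybenzyl group on the amide nitrogen would show a similar step from the 4-fluorobenzyl group of compound 1.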